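Moving one bromine: an estimate for compound 4

A few compounds are considered here, and "the series" means these few. Any claim that something is new, unique, unknown or untested is made for them only; others in the source may bear on it.

Compound 1 `O=C(CN1CCN(C(=O)c2ccc(Cl)cc2)CC1)N1CCN(CCCc2c[nH]c3ccccc23)CC1`: 98200 nM
Compound 2 `O=C(CN1CCN(C(=O)c2ccc(Br)cc2)CC1)N1CCN(CCCc2c[nH]c3ccccc23)CC1`: 71900 nM
Compound 3 `O=C(CN1CCN(C(=O)c2ccc(F)cc2)CC1)N1CCN(CCCc2c[nH]c3ccccc23)CC1`: 141000 nM

These values come from an ADME assay on HEK293 cells (Homo sapiens) for cytotoxicity, read by MTT assay, with a stated time of 72 h; on this read-out higher numbers stand for weaker inhibition and lower numbers for stronger inhibition. The three compounds differ only in the chloro, bromo or fluoro group on the aromatic ring. Compound 2 gives 71900 nM, and its values sit within the usual scatter of both neighbours, so the three cannot be told apart.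

Compound 4 `O=C(CN1CCN(C(=O)c2cccc(Br)c2)CC1)N1CCN(CCCc2c[nH]c3ccccc23)CC1` has not yet been measured. It differs from compound 2 by 3-bromophenyl in place of 4-bromophenyl on a carbonyl carbon, with 3-bromophenyl in place of 4-bromophenyl on a carbonyl carbon. The same atoms are present, joined differently.

The closest evidence comes from the three measured swaps: a 1.4-fold lower number from compound 1 to compound 2 (0.14 log units; within the scatter), a 1.4-fold higher number from compound 1 to compound 3 (0.16 log units; within the scatter) and a 2.0-fold higher number from compound 2 to compound 3 (0.29 log units; within the scatter). Each of these exchanges one group for another, and none moves the bromine, so the data hold no direct measure of such a move. They show only that, in these compounds, changes on this ring stayed small in this assay. The starting point is therefore compound 2 with its 71900 nM, and no clear direction can be expected.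

The expected change is a 1.1-fold higher number from compound 2 to compound 4 (0.05 log units; within the scatter), so no shift beyond the scatter is anticipated. For compound 4 the estimated value is 80000 nM, with an expected range from 45000 nM to 140000 nM.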

Compound 4, half-maximal inhibitory concentration: 80700 nM
Compound 4: middle estimate off by 1.0-fold (0.00 log units), on the low side; the range from low to high includes it.
By their numbers in this assay, from the lowest: compounds 2, 4, 1 and 3 (each within the scatter of the next).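

In this assay, the step of a 1.1-fold higher number from compound 2 to compound 4 (0.05 log units; within the scatter) gives the first direct test of moving the bromine rather than exchanging it, and it shows that 3-bromophenyl and 4-bromophenyl on this carbonyl carbon cannot be told apart. Compound 4 is equally hard to separate from the other two compounds, with a 1.2-fold lower number from compound 1 to compound 4 (0.09 log units; within the scatter) and a 1.7-fold lower number from compound 3 to compound 4 (0.24 log units; within the scatter), so among these four compounds neither exchanging the halogen nor moving the bromine takes the reading beyond the usual scatter. Nothing available here explains why these four readings stay so close together.

The compounds shown cover only chloro, bromo and fluoro groups on this ring, with 3-bromophenyl as the sole example of a moved group, so it remains open whether 3-chlorophenyl or 3-fluorophenyl would stay as close, or whether a group of another kind, such as a carboxylic acid or an amine, would shift the number beyond the scatter. On these data alone, it also remains open whether changes elsewhere in the shared core, such as a longer chain in place of the propyl chain leading to the far end of the molecule, would have a larger effect.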